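The source may report more compounds than this note shows. Statements on the series, on what has been measured and on what is new or still open speak of the compounds shown alone.

Two aryl triazenes were measured in a functional assay on L1210 cells (Mus musculus) for antiproliferative activity; on this read-out lower numbers stand for lower potency and higher numbers for higher potency (the scale is a negative logarithm). Compound 1, `CCN(C)/N=N/c1ccc(NC(N)=O)cc1`, gives 3.87 in this assay. Compound 2, `CN(C)/N=N/c1ccc([N+](=O)[O-])cc1C(N)=O`, gives 3.26 in this assay. Among the measured compounds shown here, compound 2 therefore stands as the lower of the two numbers, and its value lies beyond the scatter under that of compound 1; no single structural step links these two compounds, so the pair shows only that their values differ.

Compound 3, `CN(C)/N=N/c1ccc(S(N)(=O)=O)cc1C(N)=O`, has not yet been measured. It differs from compound 2 in one place: sulfamoyl in place of nitro on an aromatic carbon. For the measured compounds named here, nothing among the measured compounds shows what a sulfamoyl in place of a nitro on an aromatic carbon does in this assay, so the direction of the step cannot be read from the data.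

On this basis compound 3 is expected to sit close to compound 2, with a step of about a number 0.06 log units lower from compound 2 to compound 3 (within the scatter) in this assay, that is, no change beyond the scatter. The estimate for compound 3 in this assay is therefore 3.2, with a range from 2.6 to 3.8.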

Compound 3, logarithm of the reciprocal of the active concentration, log(1/C): 3.32
Compound 3: middle estimate off by 0.12 log units, on the low side; low and high end bracket the measured number.
By their numbers in this assay, from the lowest: compounds 2 and 3 (each within the scatter of the next); then compound 1.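

In this assay, the exchange of nitro for sulfamoyl on the aromatic carbon, meta to a carbamoyl group and para to a group of 5 heavy atoms, gives a step of a number 0.06 log units higher from compound 2 to compound 3 (within the scatter). Among the compounds shown here, this is the first step in the set that can be read at a single place, and it shows that this position accepts either group with no change beyond the scatter, even though sulfamoyl has 4 heavy atoms and 1 hydrogen-bond donor, while nitro has 3 heavy atoms and 0 hydrogen-bond donors. No measurement is available that would account for this result.

Going by these compounds, it remains open what an amine, a carboxylic acid or a longer chain at this position would give, and whether the same exchange would read alike on a core without the carbamoyl group. No single step joins compound 1 to either of the other two compounds, so the compounds shown do not tie compound 1 and its 3.87 to any one structural feature.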